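Swapping a Cyano for a Chloro on the Shared Core

The source may hold more compounds than are shown below. What is called first, only, known or untested is meant among the compounds shown, and "the series" means these compounds.

Measured compounds:
- compound 1, `O=S(=O)(c1ccc(F)cc1)c1cnc2cc(F)c(Cl)cc2c1-c1ccc(Cl)cc1`: 0.34 mL/min
- compound 2, `N#Cc1ccc2ncc(S(=O)(=O)c3ccc(F)cc3)c(-c3ccc(Cl)cc3)c2c1`: 0.04 mL/min

Of the compounds shown here, two have been measured in an ADME assay on microsomes from liver (Rattus norvegicus) for metabolic stability, tested at 2.5 uM; on this read-out higher numbers stand for fast clearance and lower numbers for slow clearance. Compound 1 gives 0.34 mL/min. Compound 2 gives 0.04 mL/min, the lowest of the two numbers; the gap to compound 1 lies beyond the usual scatter, so compound 2 is cleared more slowly.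

Compound 3, `O=S(=O)(c1ccc(F)cc1)c1cnc2ccc(Cl)cc2c1-c1ccc(Cl)cc1`, has not yet been measured in this assay. It differs from compound 2 in one place: chloro in place of cyano on an aromatic carbon. The cyano group that gives compound 2 its hydrogen-bond acceptor is gone, and a chloro stands there instead. Compound 1 also carries a chloro on its core, together with a fluoro, and it is the faster-cleared of the two measured compounds.

Because compound 1 shows 0.34 mL/min while compound 2 shows 0.04 mL/min, a move toward compound 1 is expected for compound 3 in this assay, with a step of a 6.3-fold higher number from compound 2 to compound 3 (0.80 log units; beyond the scatter) that goes beyond the scatter. Compound 3 is therefore estimated at 0.25 mL/min, within a range from 0.1 mL/min to 0.6 mL/min.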

Compound 3, intrinsic clearance in a liver preparation (reported as CLH), per the amount of preparation that the assay uses: 0.2 mL/min
The estimate for compound 3 lay 1.3-fold (0.10 log units) above the measured number; measured number inside the range.
By their numbers in this assay, from the lowest: compound 2; then compounds 3 and 1 (each within the scatter of the next).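

In this assay chloro in place of cyano on this aromatic carbon gives a 5.0-fold higher number from compound 2 to compound 3 (0.70 log units; beyond the scatter) and so ties the slow clearance of compound 2 to the cyano at this place, a link that compound 1 and compound 2 could not show, as they differ in more than one place. Hydrogen in place of fluoro on an aromatic carbon gives a 1.7-fold lower number from compound 1 to compound 3 (0.23 log units; within the scatter) and leaves compound 1 and compound 3 indistinguishable in this read-out, so the fluoro of compound 1 makes no difference that can be read here. Nothing measured here explains why cyano and chloro part so clearly at this position.

From the compounds shown here alone, it remains open whether cyano is unusual at this place or whether other groups on the same aromatic carbon, such as a methoxy, an amine or a carboxylic acid, would also go with slow clearance. The compounds shown also leave open how a plain hydrogen on this carbon would compare, and so whether chloro or cyano is the group that moves the number away from that baseline.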